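The source may report more compounds than this note shows. Statements on the series, on what has been measured and on what is new or still open speak of the compounds shown alone.

Of the compounds shown here, three built on one shared core have been measured in an assay on LtK cells with ATP-sensitive inward rectifier potassium channel 11 (Homo sapiens) as the target; a lower number here means that less compound is needed, a higher number that more compound is needed for the effect. Compound 1 `CC(C)=CC(=O)Nc1c(C(O)(C(F)(F)F)C(F)(F)F)ccc2ccccc12` carries a 2-methylprop-1-en-1-yl group on its carbonyl carbon, and in this assay compound 1 gives 46 nM. Compound 2 `CC(C)OC(=O)Nc1c(C(O)(C(F)(F)F)C(F)(F)F)ccc2ccccc12` has isopropoxy there instead, and compound 2 gives 1160 nM. Compound 3 `O=C(Nc1c(C(O)(C(F)(F)F)C(F)(F)F)ccc2ccccc12)c1ccc(F)cc1` carries 4-fluorophenyl on the carbonyl carbon, and compound 3 gives 70 nM. On these numbers compound 3 stands second highest, but one of its steps (a 1.5-fold higher number from compound 1 to compound 3 (0.18 log units; within the scatter)) is within the scatter, while the other (a 17-fold lower number from compound 2 to compound 3 (1.22 log units; beyond the scatter)) is large, as is a 25-fold higher number from compound 1 to compound 2 (1.40 log units; beyond the scatter).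

Compound 4 `O=C(Nc1c(C(O)(C(F)(F)F)C(F)(F)F)ccc2ccccc12)c1ccc(I)cc1` differs from compound 3 in one atom: iodo in place of fluoro on an aromatic carbon, para to a large group. For the measured compounds named here, none of the measured steps touches that ring; all three alter the group on the carbonyl carbon, so none bears directly on this change. Going by the values given here, with no measured step to lean on, the expectation is a step within the scatter, in either direction, and the expected step is a 1.2-fold lower number from compound 3 to compound 4 (0.07 log units; within the scatter). Compound 4 is therefore estimated at 60 nM in this assay, with a range from 20 nM to 200 nM.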

Compound 4, half-maximal effective concentration: 154 nM
Compound 4: middle estimate off by 2.6-fold (0.41 log units), on the low side; low and high end bracket the measured number.
By their numbers in this assay, from the lowest: compounds 1 and 3 (each within the scatter of the next); then compound 4; then compound 2.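

For the compounds shown here, on the aromatic carbon para to a large group, a ring position none of the earlier steps touched, the atom present does matter in this assay: iodo in place of fluoro gives a modest change (a 2.2-fold higher number from compound 3 to compound 4 (0.34 log units; beyond the scatter)). On the carbonyl carbon, 4-iodophenyl still keeps a clear lead over isopropoxy (a 7.5-fold lower number from compound 2 to compound 4 (0.88 log units; beyond the scatter)) but, unlike 4-fluorophenyl, no longer stays within the scatter of 2-methylprop-1-en-1-yl (a 3.3-fold higher number from compound 1 to compound 4 (0.52 log units; beyond the scatter)). Nothing measured here explains why the swap of these two atoms has this effect.

From the compounds shown here alone, whether chloro or bromo on the same carbon would fall between fluoro and iodo remains open. Also open, going by these compounds, is how a group other than a halogen, such as methoxy or an amine, would behave at this position.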